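Piperidine nitrogen substituent and microsomal clearance

This account rests on a few compounds, and the source may have more. Where it says the series, first, only, none or still open, it means among the compounds named here.

The series shares one core, shown as compound 1 `C=CC(=O)Nc1cccc(-n2c(-c3nc(-c4cnn(C5CCN(C)CC5)c4)cnc3N)nc3ccccc32)c1`; compound 2 `C=CC(=O)Nc1cccc(-n2c(-c3nc(-c4cnn(C5CCN(C)CC5)c4)cnc3N)nc3ccncc32)c1` and compound 3 `C=CC(=O)Nc1cccc(-n2c(-c3nc(-c4cnn(C5CCN(CC)CC5)c4)cnc3N)nc3ccccc32)c1` vary it. In an ADME assay on liver for metabolic stability, with Liver microsome (Homo sapiens) as the target, using microsomes (a higher number here means faster removal of the compound, a lower number slower removal), compound 1 gives 120 mL.min-1.g-1, compound 2 gives 68 mL.min-1.g-1 and compound 3 gives 197 mL.min-1.g-1. Compound 3 therefore carries the highest number of the three; its gap to compound 1 lies within the scatter, whereas the number for compound 2 sits lower by more than the scatter. Among the measured compounds shown here, the one single-point step recorded is a 1.6-fold higher number from compound 1 to compound 3 (0.22 log units; within the scatter).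

Compound 4 `C=CC(=O)Nc1cccc(-n2c(-c3nc(-c4cnn(C5CCN(C(=O)CN(C)C)CC5)c4)cnc3N)nc3ccccc32)c1` is not yet measured. It differs from compound 3 by ((dimethylamino)methyl)carbonyl in place of ethyl on an amine nitrogen in a ring. For the measured compounds named here, the only step that touches the same ring nitrogen is a 1.6-fold higher number from compound 1 to compound 3 (0.22 log units; within the scatter), a small alkyl change that stayed within the scatter; the present change is larger and of a different kind, and no measured pair covers it. The expectation for compound 4 in this assay is therefore no step beyond the scatter, with a wide range to reflect the lack of precedent, meaning an expected step of a 1.3-fold lower number from compound 3 to compound 4 (0.12 log units; within the scatter). Compound 4 is estimated at 150 mL.min-1.g-1, expected to fall between 60 mL.min-1.g-1 and 380 mL.min-1.g-1.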

Compound 4, intrinsic clearance in microsomes: 66 mL.min-1.g-1
The estimate for compound 4 lay 2.3-fold (0.36 log units) above the measured number; the range from low to high includes it.
By their numbers in this assay, from the lowest: compounds 4, 2, 1 and 3 (each within the scatter of the next, the first and the last beyond it).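

In this assay the amine nitrogen in the ring now gives a step beyond the scatter, with a 3.0-fold lower number from compound 3 to compound 4 (0.47 log units; beyond the scatter) on going from ethyl to ((dimethylamino)methyl)carbonyl, whereas the earlier change at that nitrogen with a 1.6-fold higher number from compound 1 to compound 3 (0.22 log units; within the scatter) stayed within it. Read against methyl instead, the same group gives a 1.8-fold lower number from compound 1 to compound 4 (0.26 log units; within the scatter) and stays within the scatter, so the step beyond the scatter holds only against ethyl, and compound 4 cannot be told apart from compound 1 on these numbers. No evidence in hand accounts for the step at this nitrogen.

Still open, from the compounds shown here alone, is which part of ((dimethylamino)methyl)carbonyl goes with the step, the carbonyl or the dimethylamino end; a plain acetyl group on the same nitrogen, or a dimethylaminoethyl chain joined without the carbonyl, would separate the two. Also open, going by these compounds, is whether the step carries over to the changed core of compound 2, since ((dimethylamino)methyl)carbonyl appears here only on the core of compound 1.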